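Lengthening the Ketone Chain of Compound 1 Toward Compound 4

The compounds below may be only part of what the source reports. "The series", "measured", "known", "first", "only" and "open" are said of these compounds alone.

compound 1 `CCCC(=O)c1c(OC)c(Cl)c(OC)c(Cl)c1OC`: 144000 nM
compound 2 `CCCCCC(=O)c1c(O)c(Cl)c(O)c(Cl)c1O`: 102000 nM
compound 3 `CCCCCCCC(=O)c1c(O)c(Cl)c(O)c(Cl)c1O`: 88500 nM

In an ADME assay on the whole organism (strain S2) for cytotoxicity, with Drosophila as the target, read by WST assay (on this read-out higher numbers stand for lower toxicity in this test and lower numbers for higher toxicity in this test), compound 1 gives the highest of the three numbers, but compound 2 and compound 3 both lie within the scatter of it, so no order among the three can be claimed. Compound 4 `CCCCCC(=O)c1c(OC)c(Cl)c(OC)c(Cl)c1OC` differs from compound 1 by ethyl in place of hydrogen on a saturated chain carbon, three bonds along the chain from a carbonyl carbon. Within the data shown here, the one measured step of a similar kind is a 1.2-fold lower number from compound 2 to compound 3 (0.06 log units; within the scatter), an ethyl group added to the ketone chain, and it stayed within the scatter. For compound 4 no step beyond the scatter is therefore expected in this assay. Compound 4 is estimated at 130000 nM, with a range from 70000 nM to 250000 nM, which means an expected step of a 1.1-fold lower number from compound 1 to compound 4 (0.04 log units; within the scatter).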

Compound 4, half-maximal cytotoxic concentration: 148000 nM
For compound 4 the middle estimate is 1.1-fold (0.06 log units) below the measured one, and the stated range covers the measured number.
By their numbers in this assay, from the lowest: compounds 3, 2, 1 and 4 (each within the scatter of the next).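

On the core of compound 1, ethyl in place of hydrogen on a saturated chain carbon, three bonds along the chain from a carbonyl carbon, gives a 1.0-fold higher number from compound 1 to compound 4 (0.01 log units; within the scatter) in this assay. This position therefore takes the change without a step beyond the scatter, and a single case no longer carries that reading: the same change on two cores in this assay, a 1.2-fold lower number (0.06 log units; within the scatter) from compound 2 to compound 3 and a 1.0-fold higher number (0.01 log units; within the scatter) from compound 1 to compound 4, 1.2-fold (0.07 log units) apart, within the scatter of two such steps

As far as these compounds go, whether a much longer chain, or a chain ending in an amine or a carboxylic acid, would move the number beyond the scatter stays open.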